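The compounds below may be only part of what the source reports. "The series", "measured", "known", "first", "only" and "open" are said of these compounds alone.

Of the compounds shown here, three have so far been measured in an assay for displacement of a labelled ligand from DNA repair protein REV1 (Homo sapiens), read by fluorescence polarization, with a stated time of 1 h; on this read-out lower numbers stand for tighter binding and higher numbers for weaker binding. Compound 1 `CCc1ccc(NC(=O)CN2CCN(c3ccc(F)cc3)CC2)cc1` gives 6500 nM, the lowest of the three numbers. Compound 2 `COC(=O)c1cc(C)sc1NC(=O)C1CCN(C(C)=O)CC1` gives 8200 nM, which lies within the scatter of compound 1. For the measured compounds named here, compound 3 `CCc1cc(C(=O)OC)c(NC(=O)C2CCN(C(C)=O)CC2)s1` gives 23700 nM; the only recorded step between two measured compounds is a 2.9-fold higher number from compound 2 to compound 3 (0.46 log units; beyond the scatter), and it concerns a different change on a different core.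

Compound 4 `N#Cc1ccc(NC(=O)CN2CCN(c3ccc(F)cc3)CC2)cc1` differs from compound 1 by cyano in place of ethyl on an aromatic carbon. Going by the values given here, no measured step bears directly on this change, and the step from compound 2 to compound 3 involves another core and another group, so there is no basis for expecting a shift beyond the scatter. Compound 4 is therefore expected to give about 6500 nM, between 2500 nM and 17000 nM, a step of no change at the digits printed from compound 1 to compound 4 (within the scatter).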

Compound 4, dissociation constant: 109000 nM
Compound 4: middle estimate off by 17-fold (1.22 log units), on the low side, outside the stated range (above it).
By their numbers in this assay, from the lowest: compounds 1 and 2 (each within the scatter of the next); then compound 3; then compound 4.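

Cyano in place of ethyl on this aromatic carbon, para to a large group, brings a 17-fold higher number from compound 1 to compound 4 (1.22 log units; beyond the scatter) in this assay on the shared core. This position is therefore sensitive to what sits on it, even though both groups have the same count of heavy atoms. Cyano adds a hydrogen-bond acceptor and a triple bond, but no measurement here explains the rise.

Going by these compounds, what an amine or a longer chain such as propyl would give at this position remains open. So does whether this change would have a similar effect on another core.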